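The source may report more compounds than this note shows. Statements on the series, on what has been measured and on what is new or still open speak of the compounds shown alone.

In an ADME assay on isolated protein for inhibition of Amine oxidase [flavin-containing] B (Homo sapiens) (on this read-out higher numbers stand for weaker inhibition and lower numbers for stronger inhibition), compound 3 `C#CCNC1CCc2c(SCCc3ccc(OC)cc3)cccc21` gives 4590 nM. Compound 2 `C#CCNC1CCc2c(SCCc3cccc(C)c3)cccc21` gives 4960 nM, and the step of a 1.1-fold lower number from compound 2 to compound 3 (0.03 log units; within the scatter) is within the scatter. For compound 1 `C#CCNC1CCc2c(SCCc3cccc(Cl)c3)cccc21` the entry in this assay reads "not determined" (no result reported), so no result was reported. Compound 4 `C#CCNC1CCc2c(SCCc3ccc(C)cc3)cccc21` differs from compound 3 in one respect: methyl in place of methoxy on an aromatic carbon. For the measured compounds named here, the only measured step that bears on this change is a 1.1-fold lower number from compound 2 to compound 3 (0.03 log units; within the scatter), where one substituted phenyl replaced another with almost no movement, so a step no larger than the scatter is expected here, with no firm direction. Compound 4 is therefore estimated at 4500 nM in this assay, within 2000 nM to 10000 nM, meaning an expected step of a 1.0-fold lower number from compound 3 to compound 4 (0.01 log units; within the scatter).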

Compound 4, half-maximal inhibitory concentration: 4520 nM
Beside the measured number, compound 4's estimate is 1.0-fold (0.00 log units) below it, within the range that was stated.
By their numbers in this assay, from the lowest: compounds 4, 3 and 2 (each within the scatter of the next).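

In this assay, exchanging methoxy for methyl at the same ring position gives a 1.0-fold lower number from compound 3 to compound 4 (0.01 log units; within the scatter), while the isolated shift of methyl from 3-methylphenyl to 4-methylphenyl gives a 1.1-fold lower number from compound 2 to compound 4 (0.04 log units; within the scatter). Among these compounds, neither the change of this substituent nor the change of its ring position moves the number beyond the scatter. Nothing given here accounts for this result. As far as these compounds go, whether a carboxylic acid or an amine on this ring, or a longer chain on the sulfur, would move the number remains open. Compound 1, with its chlorine, offers no comparison.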